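Lengthening the nitrogen substituent of compound 3

The source may hold more compounds than are shown below. What is called first, only, known or untested is meant among the compounds shown, and "the series" means these compounds.

Measured in a functional assay on MKN-45 cells (Homo sapiens) for inhibition, with a stated time of 72 h; a lower number here means a stronger inhibitor, a higher number a weaker inhibitor:
compound 1 `COc1cc(C(=O)c2ccc3c(ccn3C)c2)cc(OC)c1OC`: 11.2 nM
compound 2 `CCn1ccc2cc(C(=O)c3cc(OC)c(OC)c(OC)c3)ccc21`: 31 nM
compound 3 `COc1cc(C(=O)c2ccc3c(ccn3CO)c2)cc(OC)c1OC`: 33 nM

Compound 3 cannot be told apart from compound 2, showing a 1.1-fold higher number from compound 2 to compound 3 (0.03 log units; within the scatter), but it trails compound 1, with a 2.9-fold higher number from compound 1 to compound 3 (0.47 log units; beyond the scatter). Compound 4 `COc1cc(C(=O)c2ccc3c(ccn3CCN(C)C)c2)cc(OC)c1OC` carries (dimethylamino)methyl in place of hydroxy on a saturated chain carbon bound to an aromatic nitrogen. The closest evidence is the two changes at this place: a 2.8-fold higher number from compound 1 to compound 2 (0.44 log units; beyond the scatter), and the step to compound 3 already given. Both are modest and both raise the number, but neither compound carries an amine, so the guide is loose. A further modest rise is expected in this assay. The expected step is a 1.8-fold higher number from compound 3 to compound 4 (0.26 log units; within the scatter). Compound 4 is estimated at 60 nM, within an expected range of 18 nM to 200 nM.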

Compound 4, half-maximal inhibitory concentration: 2900 nM
For compound 4 the middle estimate is 48-fold (1.68 log units) below the measured one; measured number outside the range, above it.
By their numbers in this assay, from the lowest: compound 1; then compounds 2 and 3 (each within the scatter of the next); then compound 4.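

In this assay, this position proves far less forgiving than the modest earlier changes suggested, with the step from hydroxy to (dimethylamino)methyl giving an 88-fold higher number from compound 3 to compound 4 (1.94 log units; beyond the scatter). Placing dimethylamino on the saturated chain carbon, two bonds along the chain from the aromatic nitrogen, gives a 94-fold higher number from compound 2 to compound 4 (1.97 log units; beyond the scatter), and the whole change from the smallest substituent gives a 260-fold higher number from compound 1 to compound 4 (2.41 log units; beyond the scatter). No measurement shown here accounts for this loss of activity.

Going by these compounds, whether the loss follows the dimethylamino group itself or the longer chain remains open. A propyl chain, a 2-methoxyethyl chain or a 2-(morpholin-4-yl)ethyl chain would bear on that question.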